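This account rests on a few compounds, and the source may have more. Where it says the series, first, only, none or still open, it means among the compounds named here.

Compound 1 `CCC1(O)CCN(c2nc(C)c3cc(NC(=O)COc4ccc(OC(F)(F)F)cc4)ccc3n2)CC1` gives 116 nM in an assay on CHO-K1 cells for displacement of a labelled ligand from melanin-concentrating hormone receptor 1 (Homo sapiens), with a stated time of 2 h; a higher number here means a weaker inhibitor, a lower number a stronger inhibitor.
Compound 2 `Cc1nc(N2CCN(C(=O)C3CCC3)CC2)nc2ccc(NC(=O)COc3ccc(OC(F)(F)F)cc3)cc12` gives 84 nM in this assay.

Compound 2 sits at the low end of these two numbers, but the step of a 1.4-fold lower number from compound 1 to compound 2 (0.14 log units; within the scatter) is within the scatter, so the two compounds cannot be told apart on this evidence. A further compound, compound 3 `Cc1nc(N2CCC(O)(C3CC3)CC2)nc2ccc(NC(=O)COc3ccc(OC(F)(F)F)cc3)cc12`, differs from compound 2 in one place: 4-cyclopropyl-4-hydroxypiperidin-1-yl in place of 4-(cyclobutylcarbonyl)piperazin-1-yl on an aromatic carbon. Among the measured compounds shown here, only one measured step bears on this change. That step, a 1.4-fold lower number from compound 1 to compound 2 (0.14 log units; within the scatter), exchanged the same 4-(cyclobutylcarbonyl)piperazin-1-yl group for a 4-hydroxypiperidin-1-yl group carrying an ethyl rather than a cyclopropyl substituent, a group close to the one entering here, and it stayed within the scatter. Compound 1, which carries that ethyl-bearing group, gives 116 nM in this assay. Compound 3 is therefore expected to come out close to compound 2 and compound 1 alike, with a 1.2-fold higher number from compound 2 to compound 3 (0.08 log units; within the scatter), nothing beyond the scatter in either direction. The estimate for compound 3 is 100 nM, with a range from 40 nM to 250 nM.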

Compound 3, half-maximal inhibitory concentration: 101 nM
Beside the measured number, compound 3's estimate is 1.0-fold (0.00 log units) below it; low and high end bracket the measured number.
By their numbers in this assay, from the lowest: compounds 2, 3 and 1 (each within the scatter of the next).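

The step of a 1.2-fold higher number from compound 2 to compound 3 (0.08 log units; within the scatter) in this assay shows that this position, an aromatic carbon between two ring nitrogen atoms, can carry quite different groups without a measurable difference. The entering 4-cyclopropyl-4-hydroxypiperidin-1-yl has a hydrogen-bond donor and a three-membered carbon ring, whereas the leaving 4-(cyclobutylcarbonyl)piperazin-1-yl has no such donor, a four-membered carbon ring and a double bond outside aromatic rings, yet the step stays within the scatter. The new step of a 1.1-fold lower number from compound 1 to compound 3 (0.06 log units; within the scatter) adds a smaller comparison within the hydroxypiperidine series, cyclopropyl in place of ethyl on a saturated ring carbon, and it too stays within the scatter, so compounds 1, 2 and 3 cannot be told apart in this assay.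

No measurement is available that would explain why these groups give such similar numbers. The compounds shown leave open whether an amine or a carboxylic acid in place of the hydroxyl, or a longer chain such as butyl in place of the ethyl or cyclopropyl, would move the number beyond the scatter.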